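From thiophen-3-yl to 4-(trifluoromethyl)phenyl: working notes

The compounds below may be only part of what the source reports. "The series", "measured", "known", "first", "only" and "open" are said of these compounds alone.

Measured in a physicochemical assay for solubility, at pH 7; a lower number here means a less soluble compound, a higher number a more soluble compound:
- compound 1 `CC(C)(C)C(=O)N1Cc2c(NC(=O)c3ccc(F)cc3)n[nH]c2C1(C)C`: 235000 nM
- compound 2 `CN1CCC(C(=O)N2Cc3c(NC(=O)c4ccsc4)n[nH]c3C2(C)C)CC1`: > 225000 nM
- compound 3 `CN1CCC(C(=O)Nc2n[nH]c3c2CN(C(=O)C(C)(C)C)C3(C)C)CC1`: > 225000 nM

Compound 2 stands at > 225000 nM, which is a limit of the assay and not a number. Compound 3 also gives only a limit, > 225000 nM. Across the series, the readings are marked by the limit of > 225000 nM in this assay, at which 2 of the 3 values shown sit.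

The next compound is compound 4 `CN1CCC(C(=O)N2Cc3c(NC(=O)c4ccc(C(F)(F)F)cc4)n[nH]c3C2(C)C)CC1`, not yet measured in this assay. The change is 4-(trifluoromethyl)phenyl in place of thiophen-3-yl on a carbonyl carbon.

Going by the values given here, the only measured step is a step that the limit leaves unreadable from compound 1 to compound 3, so no size can be carried over from it. That step also involves a change on a carbonyl carbon. With compound 2 known only as a limit, the starting point is open as well. Among the compounds with values here, the one numerical anchor is compound 1, which carries 4-fluorophenyl on a carbonyl carbon and reads 235000 nM. On that reading, compound 4 is expected to stay close to the limit, with at most a modest fall in this assay, and it may again return only a limit. The expected step is an at least 1.1-fold lower number from compound 2 to compound 4 (0.05 log units; that floor lies within the scatter), an estimate only. For compound 4 the estimated value is 200000 nM, with an expected range of 80000 nM to 300000 nM.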

Compound 4, solubility: 191000 nM
Estimate against measurement, compound 4: 1.0-fold (0.02 log units) above; the measured number falls inside the stated range.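

Compound 2 gives > 225000 nM, which is a limit of the assay and not a number, so any change starting from it can be read only as a floor. In this assay, swapping thiophen-3-yl for 4-(trifluoromethyl)phenyl at a carbonyl carbon whose other neighbours are amide-type nitrogen gives an at least 1.1-fold lower number from compound 2 to compound 4 (0.07 log units; that floor lies within the scatter). The earlier step cannot be read at all, whereas this one can be read in part. Compound 4 gives 191000 nM, so this position now has a measured number with a group of 10 heavy atoms in place of one of 5.

The true size of the step remains open, and the floor does not establish a real difference at this position; the readings are still bounded by one ceiling: the limit of > 225000 nM in this assay, at which 2 of the 4 values shown sit. Also open is how this assay would read with an amine or a carboxylic acid on the phenyl ring at this position, since the compounds shown carry only fluorine-bearing phenyl groups and thiophen-3-yl on a carbonyl carbon of this kind.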